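The source may hold more compounds than are shown below. What is called first, only, known or untested is meant among the compounds shown, and "the series" means these compounds.

Measured in an assay on CHO cells for agonist activity at Neuronal acetylcholine receptor; alpha3/alpha6/beta2/beta3 (Homo sapiens), read by FLIPR and calcium flux; a higher number here means a larger maximal response, a lower number a smaller maximal response:
compound 1 `CC(=O)N1CC2CC(C1)N2` gives 100%;
compound 2 `CC(C)C(=O)N1CC2CC(C1)N2` gives 45%.

Compound 2 stands lowest of the two values. Among the compounds with values here, the only step known is a number 55 percentage points lower from compound 1 to compound 2 (beyond the scatter), a large fall. Compound 3 `O=C(C1CCC1)N1CC2CC(C1)N2` has not yet been measured. The change is cyclobutyl in place of isopropyl on a carbonyl carbon. Within the data shown here, the one measured step bears on it only loosely, since the group on the carbonyl carbon is varied again and that step went down strongly. A further small fall, or none beyond the scatter, is therefore expected, estimated as a number 10 percentage points lower from compound 2 to compound 3 (within the scatter). Compound 3 is expected to give 35%, with a range from 15% to 60%.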

Compound 3, largest response reached (Emax), in percent of the reference or control that the assay uses: 80%
Compound 3: the middle estimate sits 45 percentage points below what was measured, and the stated range ends below it.
By their numbers in this assay, from the lowest: compound 2; then compound 3; then compound 1.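

In this assay, the maximal response at this position does not simply fall as the group on the carbonyl carbon grows: a number 35 percentage points higher from compound 2 to compound 3 (beyond the scatter) with cyclobutyl in place of isopropyl, although cyclobutyl has more heavy atoms and carries a ring. Cyclobutyl does not fully match methyl, with a number 20 percentage points lower from compound 1 to compound 3 (beyond the scatter) as a modest loss. No available evidence bears on the difference between these groups.

Still open, going by these compounds, is whether cyclopropyl or cyclopentyl would behave like cyclobutyl on this carbonyl carbon. The response to a longer open chain or to a group bearing an amine is also unknown.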